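The compounds below may be only part of what the source reports. "The series", "measured", "known", "first", "only" and "open" are said of these compounds alone.

Measured compounds:
Compound 1 `COc1cc(-c2cc(-c3ccc(N)cc3)nc(-c3ccccc3)n2)cc(OC)c1OC`
Compound 2 `COc1cc(-c2cc(-c3ccccc3)nc(-c3ccccc3)n2)cc(OC)c1OC`
Compound 3 `COc1cc(-c2cc(-c3ccc(O)cc3)nc(-c3ccccc3)n2)cc(OC)c1OC`

In a functional assay on HT-29 cells (Homo sapiens) for inhibition, read by MTT assay, with a stated time of 48 h (on this read-out higher numbers stand for weaker inhibition and lower numbers for stronger inhibition), compound 2 gives 7930 nM, and compound 3 gives 11300 nM. Compound 1 reaches only the limit > 25000 nM (the limit of > 25000 nM in this assay, at which 1 of the 3 values shown sits). Compound 2 holds the lower of the two numbers, yet a 1.4-fold higher number from compound 2 to compound 3 (0.15 log units; within the scatter), so the two cannot be separated. Compound 4 `COc1cc(-c2cc(-c3ccc(Cl)cc3)nc(-c3ccccc3)n2)cc(OC)c1OC` differs from compound 2 by chloro in place of hydrogen on an aromatic carbon. Going by the values given here, no measured step swaps in a chloro; the nearest comparisons are an at least 3.1-fold lower number from compound 1 to compound 2 (0.49 log units; beyond the scatter) and an at least 2.2-fold lower number from compound 1 to compound 3 (0.34 log units; beyond the scatter), both leaving the amino analogue, while a 1.4-fold higher number from compound 2 to compound 3 (0.15 log units; within the scatter). The substituent swap on this ring thus moved little once the amino was gone, so compound 4 is expected to stay near compound 2, with a 1.3-fold lower number from compound 2 to compound 4 (0.12 log units; within the scatter) within the scatter; compound 4 is estimated at 6000 nM (range 2500 nM to 15000 nM).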

Compound 4, half-maximal inhibitory concentration: 6230 nM
Estimate against measurement, compound 4: 1.0-fold (0.02 log units) below; measured number inside the range.
By their numbers in this assay, from the lowest: compounds 4, 2 and 3 (each within the scatter of the next). At a limit, above all of these: compound 1.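

In this assay, chloro on this aromatic carbon, para to a large group, cannot be told apart from hydrogen, a 1.3-fold lower number from compound 2 to compound 4 (0.10 log units; within the scatter), or from hydroxy, a 1.8-fold lower number from compound 3 to compound 4 (0.26 log units; within the scatter). Only the amino analogue stands apart, an at least 4.0-fold lower number from compound 1 to compound 4 (0.60 log units; beyond the scatter), and that step starts from a limit of the assay. Hydrogen, hydroxy and chloro thus form one group at this position, with amino the sole compound going against it. Going by these compounds, whether a methoxy, a trifluoromethyl or a carboxylic acid here would stay with these three remains open.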